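A few compounds are considered here, and "the series" means these few. Any claim that something is new, unique, unknown or untested is made for them only; others in the source may bear on it.

Measured so far in a functional assay on cells (Homo sapiens) for cytotoxicity; on this read-out lower numbers stand for higher toxicity in this test and higher numbers for lower toxicity in this test:
compound 1 `O=C1N(CCCCCCOc2ccc(C(F)(F)F)cc2)CCN1c1ccncn1`: > 25000 nM
compound 2 `O=C1N(CCCCCCOc2ccc(Br)cc2)CCN1c1ccncn1`: > 25000 nM

In this assay compound 1 gives > 25000 nM, which is a limit of the assay and not a number. In this assay compound 2 likewise gives only a limit, > 25000 nM. Every value shown sits at the limit of > 25000 nM in this assay, at which 2 of the 2 values shown sit. Going by the values given here, compound 1 therefore stands on a limit only, with no number to place it against the one other value shown, and the single measured step, a step that the two limits leave unreadable from compound 1 to compound 2, has no readable size.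

Compound 3 `O=C1N(CCCCCCOc2ccc(C(F)(F)F)cc2)CCN1c1ccccc1` differs from compound 1 by phenyl in place of pyrimidin-4-yl on an amide-type nitrogen in a ring. Among the compounds with values here, no measured step touches this position, and the bromo-for-trifluoromethyl step offers no readable size from which a direction could be taken. The expectation for compound 3 in this assay is therefore a value again at the limit, meaning an estimated step of a number no higher from compound 1 to compound 3 (the limit leaves the size open). Compound 3 is estimated at 25000 nM, with a range from 10000 nM to 60000 nM.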

Compound 3, half-maximal cytotoxic concentration: > 25000 nM
Compound 3: a limit, no number; the forecaster's own chance of this, stated with the estimate: 80%; the middle value lies on the limit itself.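

Compound 1 and compound 3 each stand on a limit in this assay, not on a number, so no step between them can be read: the limit of > 25000 nM in this assay, at which 3 of the 3 values shown sit.

The compounds shown leave open whether exchanging pyrimidin-4-yl for phenyl, or trifluoromethyl for bromo, changes this read-out at all.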